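Chloro for hydrogen on the core of compound 1

A few compounds are considered here, and "the series" means these few. Any claim that something is new, unique, unknown or untested is made for them only; others in the source may bear on it.

Going by the values given here, two benzyl-substituted analogues on a shared core have numbers so far. Compound 1 `ClCc1ccc(Cn2cnc3c(Cl)ncnc32)cc1` is tested in a functional assay on HCT-116 cells (Homo sapiens) for cytotoxicity, read by sulforhodamine B assay, with a stated time of 48 h (a lower number here means a stronger inhibitor of growth, a higher number a weaker inhibitor of growth), and gives 1120 nM. Compound 2 `ClCc1cccc(Cn2cnc3c(Cl)ncnc32)c1` gives 1470 nM in this assay. The two numbers sit within the scatter of each other, so no difference between compound 1 and compound 2 is resolved; compound 1 is simply the reference for the next change. Compound 3 `ClCc1ccc(Cn2cnc3c(Cl)nc(Cl)nc32)cc1` has not yet been tested in this assay. Its difference from compound 1 is chloro in place of hydrogen on an aromatic carbon. Among the compounds with values here, no measured pair shows what such a change does here, so the expectation for the step from compound 1 to compound 3 rests on the change alone: no shift beyond the scatter is expected in either direction, and the estimated step of a 1.1-fold lower number from compound 1 to compound 3 (0.05 log units; within the scatter) reflects that. Compound 3 is estimated at 1000 nM in this assay, with a range from 400 nM to 2500 nM.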

Compound 3, concentration for 50% growth inhibition: 1700 nM
Compound 3: middle estimate off by 1.7-fold (0.23 log units), on the low side, and the stated range covers the measured number.
By their numbers in this assay, from the lowest: compounds 1, 2 and 3 (each within the scatter of the next).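

Hydrogen on the aromatic carbon between two ring nitrogen atoms can give way to chloro without a resolved loss: in this assay the change gives a 1.5-fold higher number from compound 1 to compound 3 (0.18 log units; within the scatter) and stays within the scatter. Going by these compounds alone, compound 1 and compound 2 both carry hydrogen on this carbon, so this is the first reading of any substituent there, and it shows that a single chlorine at this place leaves growth inhibition unresolved from the parent. No measurement bears on why the step has this size.

The compounds shown leave open whether an amine, a methoxy group or a longer chain on this same carbon would move the number beyond the scatter. Also open, going by these compounds, is whether chloro in place of hydrogen at this carbon of compound 2 would give a similar step.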